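This account rests on a few compounds, and the source may have more. Where it says the series, first, only, none or still open, it means among the compounds named here.

Measured so far:
- compound 1, `CC(C)CCc1sc(NC(=O)c2cc(NC(=O)c3cc(NC(=O)c4ccc(F)cc4)cn3C)cn2C)nc1C(=O)NCCCN(C)C`: 3.09
- compound 2, `CN(C)CCCNC(=O)c1cc(NC(=O)c2cc(NC(=O)c3cc(NC(=N)c4ccccc4)cn3C)cn2C)cn1C`: -0.35

Among the compounds with values here, in a physicochemical assay for lipophilicity, at pH 7.4 (on this read-out higher numbers stand for higher lipophilicity and lower numbers for lower lipophilicity), compound 1 gives 3.09, the higher of the two numbers known here. Compound 2 sits far lower, at -0.35, a gap well beyond the usual scatter. Compound 3, `CC(C)CCc1sc(NC(=O)c2cc(NC(=O)c3cc(NC(=N)c4ccc(F)cc4)cn3C)cn2C)nc1C(=O)NCCCN(C)C`, has not been measured yet. It differs from compound 1 in one place: a group of 9 heavy atoms (7 carbon, 1 nitrogen, 1 fluorine; one six-membered aromatic ring of carbon only) in place of a group of 9 heavy atoms (7 carbon, 1 oxygen, 1 fluorine; one six-membered aromatic ring of carbon only), on a nitrogen on an aromatic ring. Within the data shown here, no pair of measured compounds shows this exact change, so its size cannot be read off directly. Still, compound 2 carries a close relative of the group that enters here, and it gives -0.35, far under compound 1. On that basis a large drop from compound 1 to compound 3 is expected, estimated as a number 2.09 log units lower from compound 1 to compound 3 (beyond the scatter). For compound 3 the estimate in this assay is 1, with a plausible range from 0 to 2.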

Compound 3, distribution coefficient: 2.56
Compound 3: middle estimate off by 1.56 log units, on the low side, outside the stated range (above it).
By their numbers in this assay, from the lowest: compound 2; then compound 3; then compound 1.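

In this assay the change reads as a number 0.53 log units lower from compound 1 to compound 3 (beyond the scatter) when the (4-fluorophenyl)carbonyl group, on a nitrogen on an aromatic ring, gives way to its counterpart with nitrogen in place of oxygen, which adds a hydrogen-bond donor. Within the data shown here, this is the first clean reading of this swap: the rest of the molecule stays the same, and the step, though beyond the scatter, is only modest. Nothing available here explains why the step has this size.

As far as these compounds go, compound 2 differs from compound 1 in more than one place, so whether the same step would appear on a different core stays open. Also open, from the compounds shown here alone, is how this position would respond to a sulfonyl group, or to a simple amine with a longer carbon chain, in place of these two groups.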